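This account rests on a few compounds, and the source may have more. Where it says the series, first, only, none or still open, it means among the compounds named here.

Series values in a functional assay on MV4-11 cells (Homo sapiens) for antiproliferative activity, read by CCK-8 assay, with a stated time of 72 h; a higher number here means a weaker inhibitor, a lower number a stronger inhibitor:

- compound 1 `Cn1cc(-c2cccc(C(C)(C)O)c2)c2cc(C(=O)NCc3ccc(C(=O)Nc4ccccc4N)cc3)[nH]c2c1=O`: 2200 nM
- compound 2 `Cc1cc(F)cc(C)c1Oc1ccc(C(C)(C)O)cc1-c1cn(C)c(=O)c2[nH]c(C(=O)NCc3ccc(C(=O)Nc4ccccc4N)cc3)cc12`: 240 nM

Of the two measured compounds, compound 2 stands lowest at 240 nM, and the gap to compound 1 lies beyond the scatter. The next compound is compound 3 `CC(C)Oc1ccc(C(C)(C)O)cc1-c1cn(C)c(=O)c2[nH]c(C(=O)NCc3ccc(C(=O)Nc4ccccc4N)cc3)cc12`, and the change is isopropyl in place of 4-fluoro-2,6-dimethylphenyl on an oxygen on an aromatic ring. In other words, 4-fluoro-2,6-dimethylphenoxy gives way to isopropoxy, with the rest of the structure kept.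

For the measured compounds named here, only one measured step bears on this: a 9.2-fold lower number from compound 1 to compound 2 (0.96 log units; beyond the scatter), a modest step that came with 4-fluoro-2,6-dimethylphenoxy in place of hydrogen on an aromatic carbon. Going by the values given here, no measured pair exchanges one group on that oxygen for another, so the size of the new step rests on this single comparison. Compound 3 keeps the oxygen but loses the aromatic ring of the group, so part of the gain seen in a 9.2-fold lower number from compound 1 to compound 2 (0.96 log units; beyond the scatter) may be lost, and a small move to a higher number in this assay is expected. The estimated change is a 1.8-fold higher number from compound 2 to compound 3 (0.24 log units; within the scatter), and it may stay within the scatter. For compound 3 the expected value is 420 nM, with an estimated range of 160 nM to 1100 nM.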

Compound 3, half-maximal inhibitory concentration: 40 nM
Beside the measured number, compound 3's estimate is 11-fold (1.02 log units) above it, and the stated range ends above it.
By their numbers in this assay, from the lowest: compound 3; then compound 2; then compound 1.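

In this assay, the gain at this position does not depend on the aromatic ring of the group on the oxygen: isopropyl in place of 4-fluoro-2,6-dimethylphenyl gives a 6.0-fold lower number from compound 2 to compound 3 (0.78 log units; beyond the scatter), so the smaller group carries the lower number. Measured against hydrogen on the same aromatic carbon, isopropoxy gives a 55-fold lower number from compound 1 to compound 3 (1.74 log units; beyond the scatter), which sets it clearly ahead of 4-fluoro-2,6-dimethylphenoxy, whose own step was a 9.2-fold lower number from compound 1 to compound 2 (0.96 log units; beyond the scatter). Among these three compounds, the order therefore does not follow the size of the group, since hydrogen gives the highest number, isopropoxy the lowest and the larger aryl ether lies in between, and no available measurement accounts for this order.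

On these data alone, whether the number falls further with a shorter group such as methyl on that oxygen, or rises again with a longer chain such as n-butyl, remains open. Also open, as far as these compounds go, is whether the oxygen itself is needed, which an amine nitrogen carrying the same isopropyl group in its place would test against compound 3 at 40 nM in this assay.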